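The compounds below may be only part of what the source reports. "The series", "measured", "known", "first", "only" and "open" are said of these compounds alone.

Within the data shown here, compound 2, with the structure `C=C1CC[C@@H]2[C@](C)(CNCc3ccc(Br)cc3)[C@H](O)CC[C@@]2(C)[C@@H]1/C=C/C1=CCOC1=O`, gives 430 nM in a functional assay on BMMC cells (Mus musculus, strain C57BL/6) for inhibition, with stated times of 5 days and 48 h (a lower number here means a stronger inhibitor, a higher number a weaker inhibitor), and stands as the lower of the two numbers measured so far. Among the measured compounds shown here, its neighbour, compound 1 `C=C1CC[C@@H]2[C@](C)(CNCc3ccccc3)[C@H](O)CC[C@@]2(C)[C@@H]1/C=C/C1=CCOC1=O`, gives 960 nM in this assay, and the single measured step, a 2.2-fold lower number from compound 1 to compound 2 (0.35 log units; beyond the scatter), shows what adding the bromine brought. Compound 3 has the structure `C=C1CC[C@@H]2[C@](C)(CNCc3nccs3)[C@H](O)CC[C@@]2(C)[C@@H]1/C=C/C1=CCOC1=O` and differs from compound 2 in one place: 1,3-thiazol-2-yl in place of 4-bromophenyl on a saturated chain carbon bound to an amine nitrogen. For the measured compounds named here, no measured step covers an exchange of one aromatic ring for another of this kind; the only guidance is that removing the bromine-bearing ring takes away whatever the bromo step gave, so a return toward the number of compound 1 seems the most natural expectation, with wide uncertainty. For compound 3 the expected number in this assay is 900 nM, within a range of 300 nM to 2700 nM, which corresponds to an estimated step of a 2.1-fold higher number from compound 2 to compound 3 (0.32 log units; beyond the scatter).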

Compound 3, half-maximal inhibitory concentration: 700 nM
Estimate against measurement, compound 3: 1.3-fold (0.11 log units) above; the range from low to high includes it.
By their numbers in this assay, from the lowest: compounds 2, 3 and 1 (each within the scatter of the next, the first and the last beyond it).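

In this assay, 1,3-thiazol-2-yl in place of 4-bromophenyl gives a 1.6-fold higher number from compound 2 to compound 3 (0.21 log units; within the scatter), and the same ring in place of phenyl gives a 1.4-fold lower number from compound 1 to compound 3 (0.14 log units; within the scatter). On this saturated chain carbon bound to an amine nitrogen, a five-membered aromatic ring with 2 hetero atoms can therefore replace either six-membered carbon ring with no step beyond the scatter, even though compound 1 and compound 2 differ from each other by more than the scatter. No measurement here explains these numbers.

The compounds shown leave open whether the ring must be aromatic at all, since a saturated ring such as cyclohexyl could be compared in the same place. They also leave open how a longer chain, such as 2-phenylethyl, or a carboxylic acid on the ring would read in this assay.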